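Trimming the sulfonyl aryl group on the way to compound 3

The source may hold more compounds than are shown below. What is called first, only, known or untested is meant among the compounds shown, and "the series" means these compounds.

Compound 1 `CCN(CC)c1ccc2cc(C(=O)c3ccc(N4CCN(S(C)(=O)=O)CC4)cc3)oc2c1` and compound 2 `CCN(CC)c1ccc2cc(C(=O)c3ccc(N4CCN(S(=O)(=O)c5ccc(Br)c(F)c5)CC4)cc3)oc2c1` share one core and differ only in the group on a sulfonyl sulfur. In a functional assay on HeLa cells (Homo sapiens) for cytotoxicity, read by MTT assay, with a stated time of 48 h (on this read-out higher numbers stand for weaker inhibition and lower numbers for stronger inhibition), compound 1 gives only a limit, > 40000 nM. In this assay, among the compounds with values here, compound 2 gives 20700 nM, the sole actual number among the two values shown. Within the data shown here, the one measured step is an at least 1.9-fold lower number from compound 1 to compound 2 (0.28 log units; that floor lies within the scatter); its floor sits within the scatter, so it gives no firm direction. Compound 3 `CCN(CC)c1ccc2cc(C(=O)c3ccc(N4CCN(S(=O)(=O)c5ccc(F)cc5)CC4)cc3)oc2c1` differs from compound 2 by 4-fluorophenyl in place of 4-bromo-3-fluorophenyl on a sulfonyl sulfur. Among the measured compounds shown here, no measured step covers this exact change, and the only step available, an at least 1.9-fold lower number from compound 1 to compound 2 (0.28 log units; that floor lies within the scatter), was small, so a change within the scatter is expected, leaning at most slightly toward a higher number. Compound 3 is therefore estimated at 26000 nM, with a range from 10000 nM to 60000 nM. That estimate is expected to correspond to a step of a 1.3-fold higher number from compound 2 to compound 3 (0.10 log units; within the scatter).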

Compound 3, half-maximal inhibitory concentration: 21600 nM
Compound 3: middle estimate off by 1.2-fold (0.08 log units), on the high side, and the stated range covers the measured number.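

Within the data shown here, putting 4-fluorophenyl in place of 4-bromo-3-fluorophenyl on the sulfonyl sulfur gives the first comparison here between two actual numbers in this assay, and it is a 1.0-fold higher number from compound 2 to compound 3 (0.02 log units; within the scatter), so this exchange of aryl groups shows no measurable effect on the read-out. The comparison of 4-fluorophenyl with methyl is less firm: an at least 1.8-fold lower number from compound 1 to compound 3 (0.26 log units; that floor lies within the scatter) gives no clear direction, just as the earlier step from methyl did. For compound 1 there is only a limit of the assay, not a number: the limit of > 40000 nM in this assay, at which 1 of the 3 values shown sits.

On these data alone, how a phenyl group carrying an amine or a carboxylic acid, or a longer alkyl chain in place of methyl, would read on this sulfur remains open. Also open, as far as these compounds go, is whether unsubstituted phenyl would read the same as 4-fluorophenyl.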